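Swapping the Aryl Group on the Ring Nitrogen

The source may report more compounds than this note shows. Statements on the series, on what has been measured and on what is new or still open speak of the compounds shown alone.

Three compounds share one core and differ only in the aryl group on an aromatic nitrogen. Compound 1 `O=C(Nc1ccc(Oc2ccnc3[nH]ccc23)c(F)c1)c1cc2cccnc2n(-c2ccccc2)c1=O` gives 160 nM in a functional assay on HT-29 cells (Homo sapiens) for antiproliferative activity, read by MTT assay, with a stated time of 72 h; a higher number here means a weaker inhibitor, a lower number a stronger inhibitor; compound 2 `O=C(Nc1ccc(Oc2ccnc3[nH]ccc23)c(F)c1)c1cc2cccnc2n(-c2ccc(Br)cc2)c1=O` gives 120 nM; compound 3 `O=C(Nc1ccc(Oc2ccnc3[nH]ccc23)c(F)c1)c1cc2cccnc2n(-c2ccc(F)c(Cl)c2)c1=O` gives 310 nM, the highest of the three numbers. The steps to it are small: a 1.9-fold higher number from compound 1 to compound 3 (0.29 log units; within the scatter) and a 2.6-fold higher number from compound 2 to compound 3 (0.41 log units; beyond the scatter). Compound 4 `O=C(Nc1ccc(Oc2ccnc3[nH]ccc23)c(F)c1)c1cc2cccnc2n(-c2ccc(C(F)(F)F)cc2Cl)c1=O` carries a further change of this aryl group: 2-chloro-4-(trifluoromethyl)phenyl in place of 3-chloro-4-fluorophenyl on an aromatic nitrogen. Because a 1.9-fold higher number from compound 1 to compound 3 (0.29 log units; within the scatter) and because a 2.6-fold higher number from compound 2 to compound 3 (0.41 log units; beyond the scatter) were both modest, only a small shift in this assay is expected for compound 4, if any beyond the scatter. Compound 4 is therefore estimated at 350 nM, within a range from 120 nM to 1000 nM, which would mean a 1.1-fold higher number from compound 3 to compound 4 (0.05 log units; within the scatter).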

Compound 4, half-maximal inhibitory concentration: 1360 nM
Compound 4: middle estimate off by 3.9-fold (0.59 log units), on the low side; measured number outside the range, above it.
By their numbers in this assay, from the lowest: compounds 2, 1 and 3 (each within the scatter of the next, the first and the last beyond it); then compound 4.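

In this assay, for the compounds shown here, the aryl group on this aromatic nitrogen proves less forgiving than the earlier compounds suggested: the new group gives a 4.4-fold higher number from compound 3 to compound 4 (0.64 log units; beyond the scatter) and an 8.5-fold higher number from compound 1 to compound 4 (0.93 log units; beyond the scatter) and an 11-fold higher number from compound 2 to compound 4 (1.05 log units; beyond the scatter), making compound 4 the weakest inhibitor of the four. This change alters both substituents on the aryl ring at once, so the step cannot be assigned to either one. Nothing available here explains the loss.

From the compounds shown here alone, whether 2-chlorophenyl or 4-(trifluoromethyl)phenyl alone would bring such a rise remains open. So does the effect of an aryl ring carrying an amine or a carboxylic acid.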